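Working notes: terminal ring variation, compound 3 to compound 4

The source may hold more compounds than are shown below. What is called first, only, known or untested is meant among the compounds shown, and "the series" means these compounds.

Measured so far:
compound 1 `O[C@@H](c1ccccc1)[C@H]1CO[C@H](c2ccccc2)[C@@H](C/C=C/c2ccccn2)C1` — 36400 nM
compound 2 `O[C@@H](c1ccccc1)[C@H]1CO[C@H](c2ccccc2)[C@@H](C/C=C/c2cccnc2)C1` — a limit of the assay, > 100000 nM
compound 3 `O=[N+]([O-])c1ccc(/C=C/C[C@H]2C[C@@H]([C@@H](O)c3ccccc3)CO[C@@H]2c2ccccc2)cc1` — 4880 nM

In a functional assay on HL-60 cells (Homo sapiens) for cytotoxicity, read by WST assay, with a stated time of 48 h (on this read-out higher numbers stand for weaker inhibition and lower numbers for stronger inhibition), compound 3 gives 4880 nM, the lowest of the two numbers shown; the nearest, compound 1, stands at 36400 nM. Compound 2 reaches only the limit of this assay, > 100000 nM. Every measured step alters the ring at the same place: a 7.5-fold lower number from compound 1 to compound 3 (0.87 log units; beyond the scatter) and an at least 20-fold lower number from compound 2 to compound 3 (1.31 log units; beyond the scatter), while an at least 2.7-fold higher number from compound 1 to compound 2 (0.43 log units; beyond the scatter). Compound 4 `O[C@@H](c1ccccc1)[C@H]1CO[C@H](c2ccccc2)[C@@H](C/C=C/C2CCCC2)C1` is still to be measured in this assay. It differs from compound 3 as follows: cyclopentyl in place of 4-nitrophenyl on a double-bonded chain carbon bound to a double-bonded chain carbon. Within the data shown here, no measured step exchanges the aromatic ring for a non-aromatic one, so the steps to hand show only that changes at this place move the number well beyond the scatter. With compound 3 holding the lowest number at 4880 nM, removal of its 4-nitrophenyl is expected to raise the number; the expected step is a 6.1-fold higher number from compound 3 to compound 4 (0.79 log units; beyond the scatter). For compound 4 the estimate is 30000 nM, with a range from 8000 nM to 100000 nM.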

Compound 4, half-maximal inhibitory concentration: 9060 nM
For compound 4 the middle estimate is 3.3-fold (0.52 log units) above the measured one, within the range that was stated.
By their numbers in this assay, from the lowest: compounds 3 and 4 (each within the scatter of the next); then compound 1. At a limit, above all of these: compound 2.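

In this assay, a 1.9-fold higher number from compound 3 to compound 4 (0.27 log units; within the scatter), so cyclopentyl, a non-aromatic ring without nitrogen or oxygen, cannot be told apart from 4-nitrophenyl on this double-bonded chain carbon, and an aromatic ring is not needed at this place for a number in this range. The same cyclopentyl stands clear of pyridin-2-yl, with a 4.0-fold lower number from compound 1 to compound 4 (0.60 log units; beyond the scatter). Of the pyridin-3-yl compound only a limit is known, and an at least 11-fold lower number from compound 2 to compound 4 (1.04 log units; beyond the scatter) is read against it: the limit of > 100000 nM in this assay, at which 1 of the 4 values shown sits.

Open, from the compounds shown here alone, is whether a plain phenyl or a cyclohexyl at this place would stay level with compound 3 and compound 4. Also open, going by these compounds, is whether a saturated ring carrying an amine, such as piperidin-4-yl, would move the number towards that of compound 1.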